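The source may report more compounds than this note shows. Statements on the series, on what has been measured and on what is new or still open speak of the compounds shown alone.

Compound 3 `Cc1nn(-c2nc(-c3ccc(Cl)c(Cl)c3)c(SC(C)C)s2)c(C(=O)O)c1-c1cc(C#N)cc(C(F)(F)F)c1` belongs to a small set of three analogues built on a shared core, each carrying a different group at one position. In a functional assay on BJAB cells (Homo sapiens) for antiproliferative activity, with a stated time of 4 days (a lower number here means that less compound is needed, a higher number that more compound is needed for the effect), compound 3 gives 3600 nM, the second highest of the three numbers. Compound 1 `Cc1nn(-c2nc(-c3ccc(Cl)c(Cl)c3)c(SC(C)C)s2)c(C(=O)O)c1-c1ccccc1` gives 3000 nM in this assay, and a 1.2-fold higher number from compound 1 to compound 3 (0.08 log units; within the scatter). Compound 2 `Cc1nn(-c2nc(-c3ccc(Cl)c(Cl)c3)c(SC(C)C)s2)c(C(=O)O)c1Cc1ccccc1[N+](=O)[O-]` gives 20000 nM in this assay. Between these two, a 5.6-fold lower number from compound 2 to compound 3 (0.74 log units; beyond the scatter), while a 6.7-fold higher number from compound 1 to compound 2 (0.82 log units; beyond the scatter).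

Compound 4 `Cc1ccc(-c2c(C)nn(-c3nc(-c4ccc(Cl)c(Cl)c4)c(SC(C)C)s3)c2C(=O)O)cc1` has not yet been measured in this assay. It differs from compound 3 at one place: 4-methylphenyl in place of 3-cyano-5-(trifluoromethyl)phenyl on an aromatic carbon. The step that bears most directly on this is the exchange of one aryl group for another from compound 1 to compound 3, which stayed within the scatter. The larger movement from compound 1 to compound 2 involved a group of a different kind and is less informative here. Compound 4 is therefore expected to show a 1.1-fold lower number from compound 3 to compound 4 (0.04 log units; within the scatter), which is within the scatter. Compound 4 is estimated at 3300 nM in this assay, with a range from 1500 nM to 8000 nM.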

Compound 4, half-maximal effective concentration: 3800 nM
Compound 4: middle estimate off by 1.2-fold (0.06 log units), on the low side; the measured number falls inside the stated range.
By their numbers in this assay, from the lowest: compounds 1, 3 and 4 (each within the scatter of the next); then compound 2.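

Replacing 3-cyano-5-(trifluoromethyl)phenyl with 4-methylphenyl at this position does not separate the two compounds in this assay, which show a 1.1-fold higher number from compound 3 to compound 4 (0.02 log units; within the scatter), even though the entering group has no nitrile, no trifluoromethyl and fewer heavy atoms. Methyl in place of hydrogen on the plain phenyl also stays within the scatter, with a 1.3-fold higher number from compound 1 to compound 4 (0.10 log units; within the scatter), so the three directly attached aryl groups now read alike, while the 2-nitrobenzyl group remains apart, with a 5.3-fold lower number from compound 2 to compound 4 (0.72 log units; beyond the scatter). Nothing available here explains why these aryl groups read alike or why the 2-nitrobenzyl group differs.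

Plain benzyl would be needed to tell whether the separation of compound 2 goes with its carbon bridge or with its nitro group. Going by these compounds, how a hydroxyl or an amine on the phenyl would read also remains open.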